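Adding Chloro to Compound 2

This account rests on a few compounds, and the source may have more. Where it says the series, first, only, none or still open, it means among the compounds named here.

Of the compounds shown here, three have so far been measured in a functional assay on MCF7 cells (Homo sapiens) for antiproliferative activity, read by MTT assay, with a stated time of 72 h; on this read-out lower numbers stand for stronger inhibition and higher numbers for weaker inhibition. Compound 1 `C/C(=N\NC(=O)c1cccc(S(=O)(=O)N2CCOCC2)c1)c1ccc(O)cc1` reports only a limit, > 100000 nM. Compound 2 `O=C(N/N=C/c1ccccc1O)c1cccc(S(=O)(=O)N2CCOCC2)c1` gives 29100 nM, the higher of the two actual numbers. Compound 3 `CCN(CC)c1ccc(/C=N/NC(=O)c2cccc(S(=O)(=O)N3CCOCC3)c2)c(O)c1` gives 3520 nM.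

Compound 4 `O=C(N/N=C/c1cc(Cl)ccc1O)c1cccc(S(=O)(=O)N2CCOCC2)c1` has not yet been measured and differs from compound 2 in one place: chloro in place of hydrogen on an aromatic carbon. This is chloro in place of hydrogen on an aromatic carbon, para to a hydroxy group.

Among the compounds with values here, only one measured step bears on this change: an 8.3-fold lower number from compound 2 to compound 3 (0.92 log units; beyond the scatter), which lies beyond the scatter. It came from diethylamino in place of hydrogen on an aromatic carbon, so it shows that a new group on this ring can lower the number. Chloro is a different group, which makes this a loose guide. A smaller drop in the same direction is therefore expected in this assay, estimated as a 2.2-fold lower number from compound 2 to compound 4 (0.35 log units; beyond the scatter). The expected value for compound 4 is 13000 nM, with an estimated range from 4500 nM to 45000 nM.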

Compound 4, half-maximal inhibitory concentration: 16500 nM
Estimate against measurement, compound 4: 1.3-fold (0.10 log units) below, within the range that was stated.
By their numbers in this assay, from the lowest: compound 3; then compounds 4 and 2 (each within the scatter of the next). At a limit, above all of these: compound 1.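

In this assay, going from 2-hydroxyphenyl to 5-chloro-2-hydroxyphenyl gives a 1.8-fold lower number from compound 2 to compound 4 (0.25 log units; within the scatter), so a chloro at this carbon, para to a hydroxy group, leaves the number within the scatter of the value without it. Within the data shown here, this shows that a new group on this ring need not produce a clear change, unlike diethylamino, which gave an 8.3-fold lower number from compound 2 to compound 3 (0.92 log units; beyond the scatter) and so far was the only such step available. Nothing measured here offers an explanation for the size of the chloro step.

The compounds shown leave open whether another group at this same carbon, such as an amine, a methoxy group or a carboxylic acid, would give a step beyond the scatter. They also leave open whether chloro on a different carbon of this ring would behave as it does here.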